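A Sulfinyl Chain in Place of Butylamino

This account rests on a few compounds, and the source may have more. Where it says the series, first, only, none or still open, it means among the compounds named here.

Measured so far:
compound 1, `CCCCNc1nc(N)c2nc(O)n(Cc3ccccc3)c2n1`, 0.1 mg/kg
compound 2, `Nc1ncnc2c1nc(O)n2Cc1ccc(F)cc1`, 30 mg/kg

In a functional assay on the whole organism for activation, with Mus musculus as the target (on this read-out higher numbers stand for an effect only at larger amounts of compound and lower numbers for an effect already at smaller amounts), compound 1 gives 0.1 mg/kg, the lowest of the two numbers. Compound 2 gives 30 mg/kg in this assay; the gap between the two lies well beyond the usual scatter. Compound 3, `CCCC[S+]([O-])c1nc(N)c2nc(O)n(Cc3ccccc3)c2n1`, has not yet been measured. It differs from compound 1 in one place: a group of 6 heavy atoms (4 carbon, 1 oxygen, 1 sulfur; no ring) in place of a group of 5 heavy atoms (4 carbon, 1 nitrogen; no ring), on an aromatic carbon. The butylamino group carried one hydrogen-bond donor, and the group that enters carries none. Among the compounds with values here, no measured pair shows a change of this kind, so the size of the step in this assay is uncertain; a rise of modest size from compound 1 to compound 3 is expected, a 10-fold higher number from compound 1 to compound 3 (1.00 log units; beyond the scatter). For compound 3 the estimated minimum effective dose is 1 mg/kg, with a range from 0.1 mg/kg to 10 mg/kg.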

Compound 3, minimum effective dose: 1 mg/kg
The estimate for compound 3 equals the measured number at the digits printed; low and high end bracket the measured number.
By their numbers in this assay, from the lowest: compound 1; then compound 3; then compound 2.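

At this position, on an aromatic carbon between two ring nitrogen atoms, the sulfinyl chain in place of butylamino gives in this assay a 10-fold higher number from compound 1 to compound 3 (1.00 log units; beyond the scatter), so the number responds to what stands here even when the chain itself is kept. Compound 3 still gives a measured minimum effective dose of 1 mg/kg with no hydrogen-bond donor in the entering group, so a donor in this group is not required for an effect in the whole animal. Nothing measured here gives a cause for the step.

The compounds shown leave open how a butoxy, butylthio or butylsulfonyl chain would compare at this position, which would help separate the contributions of the linking atom and the oxygen on sulfur. They also leave open whether a propyl or pentyl chain on the sulfinyl sulfur would shift the number in this assay.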